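Dithiocarbamate amides: adding a (2-phenylethenyl)carbonyl arm

This account rests on a few compounds, and the source may have more. Where it says the series, first, only, none or still open, it means among the compounds named here.

Measured so far in a functional assay on SMMC-7721 cells (Homo sapiens) for cytotoxicity, read by MTT assay, with a stated time of 72 h; on this read-out lower numbers stand for stronger inhibition and higher numbers for weaker inhibition:
compound 1, `COc1ccc(NC(=O)CSC(=S)N[C@H]2CCOC2=O)cc1`: > 128000 nM
compound 2, `O=C(CCl)Nc1ccc(C(=O)/C=C/c2ccc([N+](=O)[O-])cc2)cc1`: 9060 nM
compound 3, `COc1cc(/C=C/C(=O)c2ccc(NC(=O)CCl)cc2)cc(OC)c1OC`: 3000 nM

Among the compounds with values here, compound 1 reaches only the limit of this assay, > 128000 nM, and is the single member sitting at the limit of > 128000 nM in this assay, at which 1 of the 3 values shown sits. Compound 2 gives 9060 nM and compound 3 gives 3000 nM; both carry a (2-phenylethenyl)carbonyl group. Compound 4, `O=C(CSC(=S)N[C@H]1CCOC1=O)Nc1ccc(C(=O)/C=C/c2ccccc2)cc1`, is not yet measured; it differs from compound 1 by (2-phenylethenyl)carbonyl in place of methoxy on an aromatic carbon. Within the data shown here, no step between two measured compounds is available, so the size of this move is open. Since compounds 2 and 3, which carry the entering group, return numbers inside the window, compound 4 is expected to move to a lower number, a gain of an at least 8.5-fold lower number from compound 1 to compound 4 (0.93 log units; beyond the scatter). Compound 4 is estimated at 15000 nM, between 4000 nM and 60000 nM.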

Compound 4, half-maximal inhibitory concentration: > 128000 nM
Compound 4 ended at the assay's limit; the forecaster's own chance of this, stated with the estimate: 25%; middle value at least 8.5-fold (0.93 log units) from the limit.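

No step can be read from compound 1 to compound 4, as both stand at a limit rather than a number in this assay: the limit of > 128000 nM in this assay, at which 2 of the 4 values shown sit.

Left open is whether (2-phenylethenyl)carbonyl in place of methoxy changes cytotoxicity at all, and by how much.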